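Dropping the Pentylphenyl Arm from the Triazole Series

The source may hold more compounds than are shown below. What is called first, only, known or untested is meant among the compounds shown, and "the series" means these compounds.

Compound 3 `CCCCCc1ccc(-c2cn(C[C@H](O)[C@H]3OC(=O)C(OCc4ccccc4)=C3OCc3ccccc3)nn2)cc1` gives 9890 nM in a functional assay on CFPAC-1 cells (Homo sapiens) for antiproliferative activity, read by MTT assay, with a stated time of 72 h (a higher number here means a weaker inhibitor, a lower number a stronger inhibitor), the lowest of the three numbers shown. Compound 1 `CC(C)(C)c1cn(C[C@H](O)[C@H]2OC(=O)C(OCc3ccccc3)=C2OCc2ccccc2)nn1` gives 54900 nM and compound 2 `O=C1O[C@H]([C@@H](O)Cn2cc(C3CC3)nn2)C(OCc2ccccc2)=C1OCc1ccccc1` gives 47700 nM; the step of a 1.2-fold lower number from compound 1 to compound 2 (0.06 log units; within the scatter) stays within the scatter, whereas a 5.6-fold lower number from compound 1 to compound 3 (0.74 log units; beyond the scatter) and a 4.8-fold lower number from compound 2 to compound 3 (0.68 log units; beyond the scatter) are modest but beyond it. Compound 4 `O=C1O[C@H]([C@@H](O)Cn2ccnn2)C(OCc2ccccc2)=C1OCc1ccccc1` carries hydrogen in place of 4-pentylphenyl on an aromatic carbon. The two steps that bear on this change both run toward the 4-pentylphenyl group, and the reverse move, its complete removal, is expected to raise the number by a modest step. Compound 4 keeps an even smaller group than compound 1 or compound 2, so a number around theirs or somewhat higher is expected. Compound 4 is therefore estimated at 65000 nM, a step of a 6.6-fold higher number from compound 3 to compound 4 (0.82 log units; beyond the scatter), within 25000 nM to 170000 nM.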

Compound 4, half-maximal inhibitory concentration: > 100000 nM
Compound 4: no number, only a limit (the forecaster's own chance of this, stated with the estimate: 25%); middle value at least 1.5-fold (0.18 log units) from the limit.
By their numbers in this assay, from the lowest: compound 3; then compounds 2 and 1 (each within the scatter of the next). At a limit, above all of these: compound 4.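

Compound 4 has no number in this assay, only a limit: the limit of > 100000 nM in this assay, at which 1 of the 4 values shown sits. Replacing the 4-pentylphenyl group with hydrogen gives an at least 10-fold higher number from compound 3 to compound 4 (1.00 log units; beyond the scatter), and replacing cyclopropyl gives an at least 2.0-fold higher number from compound 2 to compound 4 (0.32 log units; beyond the scatter), so even this small group, not only the large arm, separates from hydrogen at this aromatic carbon. For tert-butyl the step is an at least 1.8-fold higher number from compound 1 to compound 4 (0.26 log units; that floor lies within the scatter), so that comparison stays unsettled.

The compounds shown leave open whether a plain pentyl chain without the aromatic ring would match compound 3. They also leave open whether an amine on the end of that arm would.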